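This account rests on a few compounds, and the source may have more. Where it says the series, first, only, none or still open, it means among the compounds named here.

Measured compounds:
Compound 1, `COc1ccc(NC(=O)c2ccc(-c3cnc(N4CCCN(C)CC4)nc3)cc2O)cc1Cl`: 6000 nM
Compound 2, `CN1CCN(c2ncc(-c3ccc4c(NC5CCCCC5)ccnc4c3)cn2)CC1`: 98000 nM

In a physicochemical assay for solubility, read by LC-MS, measured as thermodynamic solubility, with a stated time of 24 h, at pH 7.4 (on this read-out higher numbers stand for higher solubility and lower numbers for lower solubility), compound 2 gives 98000 nM, the highest of the two numbers shown. The nearest, compound 1, gives 6000 nM in this assay, a gap well beyond the scatter of the method. Compound 3, `CN1CCN(c2ncc(-c3ccc4c(N[C@@H]5CCCC[C@H]5O)ccnc4c3)cn2)CC1`, has not yet been measured in this assay. It differs from compound 2 in one place: hydroxy in place of hydrogen on a saturated ring carbon, so that the cyclohexylamino of compound 2 becomes (2-hydroxycyclohexyl)amino in compound 3. For the measured compounds named here, no measured pair here shows this same change, so no step can be read off from the numbers, and any expectation rests on the value of compound 2 alone. A small step upward, which may still lie within the scatter, is expected: a 1.5-fold higher number from compound 2 to compound 3 (0.18 log units; within the scatter). Compound 3 is therefore estimated at 150000 nM, with a likely range from 50000 nM to 450000 nM.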

Compound 3, solubility: 980000 nM
For compound 3 the middle estimate is 6.5-fold (0.82 log units) below the measured one; measured number above the stated range.
By their numbers in this assay, from the lowest: compound 1; then compound 2; then compound 3.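

In this assay, hydroxy in place of hydrogen on a saturated ring carbon, next to the ring atom that bears a large group, gives a 10-fold higher number from compound 2 to compound 3 (1.00 log units; beyond the scatter). For the compounds shown here, this is the first step here that can be read from a single change, as compound 1 and compound 2 differ in more than one place, and it shows that the cyclohexylamino group is a position where one small group can shift this read-out beyond the scatter. Nothing in the data shown accounts for the size of this rise.

From the compounds shown here alone, whether the same step would follow from an amine or a methoxy group on that ring carbon remains open. So does whether the hydroxy would give a similar step on another carbon of the ring, or with the opposite spatial arrangement of the 2-hydroxycyclohexyl group.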